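Carbamate substituent change on a CRF-1 receptor ligand

This account rests on a few compounds, and the source may have more. Where it says the series, first, only, none or still open, it means among the compounds named here.

Measured so far:
- compound 1, `COc1nc(C)c(Nc2nc(Cl)cn([C@H](COC(=O)Nc3ccccc3)C3CC3)c2=O)cc1C`: 1.5 nM
- compound 2, `COc1nc(C)c(Nc2nc(Cl)cn([C@H](COC(=O)Nc3cccnc3)C3CC3)c2=O)cc1C`: 10 nM

In an assay on frontal cortex for displacement of a labelled ligand from corticotropin-releasing factor receptor 1 (Rattus norvegicus), with a stated time of 2 h (on this read-out higher numbers stand for weaker inhibition and lower numbers for stronger inhibition), compound 1 gives 1.5 nM, and compound 2 gives 10 nM. Within the data shown here, compound 2 therefore holds the higher of the two numbers; the only step available is a 6.7-fold higher number from compound 1 to compound 2 (0.82 log units; beyond the scatter), so the carbamate substituent clearly matters on this read-out.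

Compound 3, `CCCNC(=O)OC[C@H](C1CC1)n1cc(Cl)nc(Nc2cc(C)c(OC)nc2C)c1=O`, has not yet been measured. The change is propyl in place of pyridin-3-yl on an amide-type nitrogen. Among the measured compounds shown here, no measured pair covers an aromatic-to-alkyl exchange at this nitrogen. For the measured compounds named here, the one step that bears on the position, a 6.7-fold higher number from compound 1 to compound 2 (0.82 log units; beyond the scatter), shows that this position is sensitive, but gives no direction for a propyl group. He therefore expects compound 3 to land near compound 2, with a wide range, and estimates a 2.0-fold higher number from compound 2 to compound 3 (0.30 log units; within the scatter) in this assay. His estimate for compound 3 is 20 nM, between 5 nM and 80 nM.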

Compound 3, half-maximal inhibitory concentration: 10 nM
Beside the measured number, compound 3's estimate is 2.0-fold (0.30 log units) above it, and the stated range covers the measured number.
By their numbers in this assay, from the lowest: compound 1; then compounds 2 and 3 (each within the scatter of the next).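

In this assay the exchange of pyridin-3-yl for propyl on the amide-type nitrogen gives no change at the digits printed from compound 2 to compound 3 (within the scatter), so among the compounds shown, a ring on this nitrogen is not needed to reach the number of compound 2, and the earlier pair could not show this. The step from phenyl to the same propyl group gives a 6.7-fold higher number from compound 1 to compound 3 (0.82 log units; beyond the scatter), which leaves compound 1 with the lowest number of the three and shows that the sensitivity of this position is not simply a divide between aromatic and alkyl groups, since pyridin-3-yl and propyl fall together on the far side of phenyl. Nothing available explains why phenyl stands apart from the other two groups.

The compounds shown leave open whether cyclohexyl or benzyl on this nitrogen would stay with compound 1 or with compounds 2 and 3, and whether a longer chain such as butyl would differ from propyl. Among these compounds, with propyl as the only alkyl group here, no trend with chain length can be read at this position.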